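The source may hold more compounds than are shown below. What is called first, only, known or untested is meant among the compounds shown, and "the series" means these compounds.

Compound 3 `CC/C=C/COC1(c2ccc(Cl)cc2)SC=C(C)n2c1noc2=O` is one of three close analogues that share a core and differ only in the chain attached to the oxygen. In a functional assay on A2780/DX3 cells (Homo sapiens) for antiproliferative activity, read by MTT assay, with a stated time of 3 days (a higher number here means a weaker inhibitor, a lower number a stronger inhibitor), compound 3 gives 88000 nM. Compound 2 `CC/C=C\COC1(c2ccc(Cl)cc2)SC=C(C)n2c1noc2=O` gives 103000 nM in this assay. Compound 1 `CCCCCCCCCCCCCCCOC1(c2ccc(Cl)cc2)SC=C(C)n2c1noc2=O` reaches only the limit of this assay, > 100000 nM, so no number is known for it. Among the two numbers shown, compound 3 holds the lower one, and the step of a 1.2-fold lower number from compound 2 to compound 3 (0.07 log units; within the scatter) is within the scatter; the two cannot be placed in order.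

Compound 4 `CCCCOC1(c2ccc(Cl)cc2)SC=C(C)n2c1noc2=O` has not yet been measured in this assay. It differs from compound 3 by propyl in place of but-1-en-1-yl on a saturated chain carbon bound to an oxygen on a saturated carbon. For the measured compounds named here, no measured pair shows exactly this change, a saturated chain shorter by one carbon. Going by the values given here, the only measured step, a 1.2-fold lower number from compound 2 to compound 3 (0.07 log units; within the scatter), concerns the geometry of the double bond and stayed within the scatter, which suggests that the shape of the chain does little here. Compound 1, with its long saturated chain, sits at the limit of this assay, so a chain change is not seen to improve the number.

Compound 4 is therefore expected to give 95000 nM in this assay, between 40000 nM and 220000 nM, meaning an expected step of a 1.1-fold higher number from compound 3 to compound 4 (0.03 log units; within the scatter).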

Compound 4, half-maximal inhibitory concentration: 49000 nM
Compound 4: middle estimate off by 1.9-fold (0.29 log units), on the high side; the measured number falls inside the stated range.
By their numbers in this assay, from the lowest: compounds 4, 3 and 2 (each within the scatter of the next, the first and the last beyond it).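

In this assay, the step of a 1.8-fold lower number from compound 3 to compound 4 (0.25 log units; within the scatter) stays within the scatter, but the same change of but-1-en-1-yl to propyl measured against the other double-bond geometry, a 2.1-fold lower number from compound 2 to compound 4 (0.32 log units; beyond the scatter), is beyond it, though only modestly. This is the first separation among the compounds at this position on the chain, where the earlier comparison of double-bond geometry had shown none, and it places a saturated butoxy chain on the shared core below compound 2 in number. Compound 1 holds a limit and not a number, so the step of an at least 2.0-fold lower number from compound 1 to compound 4 (0.30 log units; that floor lies within the scatter) is only a floor and says little about how far chain length matters: the limit of > 100000 nM in this assay, at which 1 of the 4 values shown sits.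

Compound 4 differs from compounds 2 and 3 both in having a shorter chain and in lacking the double bond, and the compounds shown do not separate these two changes, which a saturated pentyl chain on the oxygen could do. Going by these compounds, it also remains open how the number would respond to an ethyl or methyl group on the oxygen, or to a chain ending in an amine or a carboxylic acid.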